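Shortening and saturating the ether chain on a thiazine core

The source may report more compounds than this note shows. Statements on the series, on what has been measured and on what is new or still open speak of the compounds shown alone.

Measured compounds in a functional assay on A2780 cells (Homo sapiens) for antiproliferative activity, read by MTT assay, with a stated time of 3 days; a higher number here means a weaker inhibitor, a lower number a stronger inhibitor:
compound 1, `CC/C=C/COC1(c2ccc(Cl)cc2)SC=C(C)n2c1noc2=O`, gives 55000 nM.
compound 2, `O=c1onc2n1C=CSC2(O)c1ccc(Cl)cc1`, gives > 100000 nM, which is a limit of the assay.
compound 3, `CCCCCCCCCCCCCCCCCCOC1(c2ccc(Cl)cc2)SC=C(C)n2c1noc2=O`, gives > 100000 nM, also a limit of the assay.

Among the measured compounds shown here, compound 1 is the only compound of the three with a number in this assay. Compound 2 stands at a limit. For the measured compounds named here, compound 3 stands at a limit as well, so that (the limit of > 100000 nM in this assay, at which 2 of the 3 values shown sit), and no step between two numbers can be drawn.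

Compound 4, `CCCCOC1(c2ccc(Cl)cc2)SC=C(C)n2c1noc2=O`, has not yet been measured in this assay. It differs from compound 1 in one place: propyl in place of but-1-en-1-yl on a saturated chain carbon bound to an oxygen on a saturated carbon. The chain attached through the oxygen thus becomes shorter by one carbon and loses its double bond, while the shared core, the chloro-substituted aromatic ring and the ether linkage are kept.

Going by the values given here, with no measured step between two numbers to lean on, the expectation rests on compound 1 alone. The step of a 1.1-fold higher number from compound 1 to compound 4 (0.04 log units; within the scatter) is expected to stay within the usual scatter, in no clear direction. Compound 4 is therefore estimated at 60000 nM, with a range from 25000 nM to 150000 nM.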

Compound 4, half-maximal inhibitory concentration: 89000 nM
For compound 4 the middle estimate is 1.5-fold (0.17 log units) below the measured one, and the stated range covers the measured number.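

In this assay, among the compounds shown here, replacing but-1-en-1-yl with propyl gives a 1.6-fold higher number from compound 1 to compound 4 (0.21 log units; within the scatter), the first step between two numbers at this position. On a saturated chain carbon bound to an oxygen on a saturated carbon, the chain can therefore lose its double bond and one carbon with a step that stays within the scatter, so these compounds do not separate the saturated chain from the unsaturated one. The series now has two numbers rather than one, but they cannot be ordered, and little of the series can yet be read as numbers: the limit of > 100000 nM in this assay, at which 2 of the 4 values shown sit.

As far as these compounds go, compound 3, with its much longer saturated chain on the same oxygen, stands at > 100000 nM, which is a limit of the assay and not a number, so the chain length at which numbers give way to that limit remains open. Also open, from the compounds shown here alone, is whether an amine or a carboxylic acid on this chain, or a phenyl ring in its place, would give a step beyond the scatter.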